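The source may report more compounds than this note shows. Statements on the series, on what has been measured and on what is new or still open speak of the compounds shown alone.

The measured compounds:

compound 1, `COc1ccc(-c2cc(N3CCC(CCNS(N)(=O)=O)CC3)ncn2)cc1`, 69800 nM
compound 2, `NS(=O)(=O)NCCC1CCN(c2cc(-c3ccc(Cl)cc3)ncn2)CC1`, 45200 nM
compound 3, `NS(=O)(=O)NCCC1CCN(c2cc(-c3cccc(Cl)c3)ncn2)CC1`, 50700 nM

All three share one core and differ only in the aryl group attached to it. In a functional assay on M21 cells (Homo sapiens) for antiproliferative activity, read by sulforhodamine B assay, with a stated time of 48 h (a lower number here means a stronger inhibitor of growth, a higher number a weaker inhibitor of growth), compound 3 stands second highest of the three numbers. Its nearest neighbour is compound 2, with a 1.1-fold higher number from compound 2 to compound 3 (0.05 log units; within the scatter); its furthest is compound 1, with a 1.4-fold lower number from compound 1 to compound 3 (0.14 log units; within the scatter). Compound 4, `NS(=O)(=O)NCCC1CCN(c2cc(-c3ccccc3F)ncn2)CC1`, has not yet been measured. The change from compound 3 to compound 4 is 2-fluorophenyl in place of 3-chlorophenyl on an aromatic carbon.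

Among the measured compounds shown here, three measured steps bear on this change, all of them swaps of one aryl group for another on the same carbon of the core: a 1.5-fold lower number from compound 1 to compound 2 (0.19 log units; within the scatter), a 1.4-fold lower number from compound 1 to compound 3 (0.14 log units; within the scatter) and a 1.1-fold higher number from compound 2 to compound 3 (0.05 log units; within the scatter). None of them moved the number beyond the scatter, whether the substituent changed its nature or its position on the phenyl ring. For the measured compounds named here, no measured step replaces chlorine with fluorine, so that part of the change has no direct precedent. On the evidence of the three steps, no step beyond the scatter is expected in this assay for compound 4, in either direction.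

Compound 4 is therefore expected to give about 52000 nM in this assay, within a range of 26000 nM to 104000 nM, which corresponds to an expected step of a 1.0-fold higher number from compound 3 to compound 4 (0.01 log units; within the scatter).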

Compound 4, concentration for 50% growth inhibition: 81800 nM
Compound 4: middle estimate off by 1.6-fold (0.20 log units), on the low side; the range from low to high includes it.
By their numbers in this assay, from the lowest: compounds 2, 3, 1 and 4 (each within the scatter of the next).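

In this assay, the 2-fluorophenyl group brings a new halogen and a new place on the phenyl ring to this aromatic carbon of the shared core, and the number stays within the scatter of all three earlier aryl groups (a 1.6-fold higher number from compound 3 to compound 4 (0.21 log units; within the scatter); a 1.8-fold higher number from compound 2 to compound 4 (0.26 log units; within the scatter); a 1.2-fold higher number from compound 1 to compound 4 (0.07 log units; within the scatter)). The flat picture that the chloro and methoxy compounds gave therefore holds across all four compounds, with none going against it, and now covers three substituents and three places on the phenyl ring, even though the step from the 4-chlorophenyl group is the widest printed among them. Nothing measured here offers an explanation for these numbers.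

The change from compound 3 to compound 4 alters the halogen and its place together, so the compounds shown cannot separate the two, and a 2-chlorophenyl or 3-fluorophenyl group would be needed to do so. From the compounds shown here alone, it also remains open whether this carbon stays as flat with an amine or a carboxylic acid on the phenyl ring, or with a saturated cyclohexyl ring in place of the phenyl ring.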